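The source may hold more compounds than are shown below. What is called first, only, known or untested is meant among the compounds shown, and "the series" means these compounds.

Measured so far in a functional assay on MCF7 cells (Homo sapiens) for cytotoxicity, read by sulforhodamine B assay, with a stated time of 48 h; a higher number here means a weaker inhibitor, a lower number a stronger inhibitor:
- compound 1 `CC1=C(/C=C/C(=O)/C=C/c2ccccc2)C(C)(C)CCC1`, 10600 nM
- compound 2 `CC1=C(/C=C/C(=O)/C=C/c2ccc(Br)cc2)C(C)(C)CCC1`, 20100 nM
- compound 3 `COc1ccc(/C=C/C(=O)/C=C/C2=C(C)CCCC2(C)C)cc1`, 19600 nM

All three compounds share one core and differ only in a single substituent on the aromatic ring. For the measured compounds named here, compound 3, which carries a methoxy group there, sits among numbers that do not separate from one another: the step of a 1.8-fold higher number from compound 1 to compound 3 (0.27 log units; within the scatter) and the step of a 1.0-fold lower number from compound 2 to compound 3 (0.01 log units; within the scatter) both stay inside the scatter of repeated measurements, so no compound can be called stronger or weaker than another on this evidence.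

Compound 4 `CC1=C(/C=C/C(=O)/C=C/c2ccc([N+](=O)[O-])cc2)C(C)(C)CCC1` is the next member of the series. The change from compound 3 is nitro in place of methoxy on an aromatic carbon. Going by the values given here, no measured step shows a nitro group directly, but two steps bear on the same position: a 1.9-fold higher number from compound 1 to compound 2 (0.28 log units; within the scatter) and a 1.8-fold higher number from compound 1 to compound 3 (0.27 log units; within the scatter), each within the scatter, and the direct comparison a 1.0-fold lower number from compound 2 to compound 3 (0.01 log units; within the scatter) shows that swapping one substituent for another at this place left the number essentially unchanged. The expectation is therefore no step beyond the scatter, expressed as a 1.1-fold lower number from compound 3 to compound 4 (0.04 log units; within the scatter). For compound 4 in this assay the estimate is 18000 nM, with a range from 7000 nM to 45000 nM.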

Compound 4, half-maximal inhibitory concentration: 5500 nM
Beside the measured number, compound 4's estimate is 3.3-fold (0.51 log units) above it, outside the stated range (below it).
By their numbers in this assay, from the lowest: compounds 4, 1, 3 and 2 (each within the scatter of the next, the first and the last beyond it).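

In this assay, this position on the aromatic ring now separates compounds, which the earlier trio with hydrogen, bromo and methoxy could not show: nitro in place of methoxy gives a stronger inhibitor (a 3.6-fold lower number from compound 3 to compound 4 (0.55 log units; beyond the scatter)), and nitro in place of bromo does the same (a 3.7-fold lower number from compound 2 to compound 4 (0.56 log units; beyond the scatter)), with both steps beyond the scatter. The gain holds only against those two groups, since nitro in place of hydrogen stays within the scatter (a 1.9-fold lower number from compound 1 to compound 4 (0.28 log units; within the scatter)), so compound 4 and compound 1 cannot be told apart and a substituent at this place cannot be said to improve on the plain ring. Nothing measured here explains why nitro differs from methoxy and bromo.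

The compounds shown leave open how an amine, a carboxylic acid or a nitrile would behave on this same aromatic carbon, and so whether any group can move the number clearly beyond that of compound 1. They also leave open whether nitro would give a similar result on a different carbon of the ring or with a change elsewhere in the shared core.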